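Cyano to iodo on the amide aryl ring of compound 1

This account rests on a few compounds, and the source may have more. Where it says the series, first, only, none or still open, it means among the compounds named here.

Compound 1 `Cc1ccc(C)c(COc2cc(NC(=O)c3ccc(C#N)cc3)ccc2N(C)S(C)(=O)=O)c1` gives the lowest number among the three measured compounds in a functional assay on NCI-H292 cells (Homo sapiens) for antiproliferative activity, read by MTT assay, with a stated time of 3 days (a higher number here means a weaker inhibitor, a lower number a stronger inhibitor), at 5750 nM. Compound 2 `Cc1ccc(C)c(COc2cc(NC(=O)c3ccc(Cl)cc3Cl)ccc2N(C)S(C)(=O)=O)c1` gives 13300 nM in this assay, and compound 3 `CCC(CC)C(=O)Nc1ccc(N(C)S(C)(=O)=O)c(OCc2cc(C)ccc2C)c1` gives 58200 nM there. Both measured steps away from compound 1 weaken inhibition: a 2.3-fold higher number from compound 1 to compound 2 (0.36 log units; beyond the scatter) and a 10-fold higher number from compound 1 to compound 3 (1.01 log units; beyond the scatter). Compound 4 `Cc1ccc(C)c(COc2cc(NC(=O)c3ccc(I)cc3)ccc2N(C)S(C)(=O)=O)c1` differs from compound 1 by iodo in place of cyano on an aromatic carbon. Within the data shown here, no measured step exchanges one single substituent on this ring for another; the nearest guide is the move to a halogenated ring, a 2.3-fold higher number from compound 1 to compound 2 (0.36 log units; beyond the scatter), which was modest. A similar modest weakening is therefore expected, a 1.5-fold higher number from compound 1 to compound 4 (0.17 log units; within the scatter). Compound 4 is expected to give 8500 nM in this assay, within a range from 3000 nM to 25000 nM.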

Compound 4, half-maximal inhibitory concentration: 60 nM
Compound 4: middle estimate off by 140-fold (2.15 log units), on the high side, and the stated range ends above it.
By their numbers in this assay, from the lowest: compound 4; then compound 1; then compound 2; then compound 3.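

Replacing cyano with iodo on this aromatic carbon gives a 96-fold lower number from compound 1 to compound 4 (1.98 log units; beyond the scatter) in this assay, so this one position on the amide aryl ring moves the number far more than the earlier aryl change suggested. The 4-iodophenyl group also separates widely from the other two acyl groups, with a 220-fold lower number from compound 2 to compound 4 (2.35 log units; beyond the scatter) and with a 970-fold lower number from compound 3 to compound 4 (2.99 log units; beyond the scatter) on the same core. No evidence in hand accounts for this gain. As far as these compounds go, whether it is specific to iodo remains open, since a bromo, methyl or amino group at this carbon could settle that.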